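Chloro on the styryl ring of the sulfonate series

The source may report more compounds than this note shows. Statements on the series, on what has been measured and on what is new or still open speak of the compounds shown alone.

Of the compounds shown here, three have numbers so far. Compound 1 `COc1ccccc1NS(=O)(=O)/C=C/c1ccccc1Cl` in an assay on U2OS cells for activation of nuclear factor erythroid 2-related factor 2 (Homo sapiens), read by chemiluminescence, with a stated time of 6 h (on this read-out lower numbers stand for an effect already at smaller amounts and higher numbers for an effect only at larger amounts of compound), gives 6350 nM. Compound 2 `COc1ccc(OS(=O)(=O)/C=C/c2ccccc2)cc1` gives 1480 nM and compound 3 `COc1ccccc1OS(=O)(=O)/C=C/c1ccccc1Cl` gives 76 nM. Compound 2 stands second highest of the three: compound 1 sits at a higher number than compound 2, beyond the scatter, while compound 3 sits at a far lower number than compound 2, also beyond the scatter. Going by the values given here, compound 2 and compound 3 differ in more than one place, so the gap between them cannot be read as a single step, and no pair of measured compounds differs in one place only.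

Compound 4 `COc1ccc(OS(=O)(=O)/C=C/c2cccc(Cl)c2)cc1` has not been measured. It differs from compound 2 by chloro in place of hydrogen on an aromatic carbon. Among the compounds with values here, since no single-point step is at hand, the direction of this change rests only on the observation that the two measured compounds carrying chloro on the styryl ring, compound 1 and compound 3, bracket compound 2 on both sides, which leaves the sign open. A moderate move toward a lower number is expected for compound 4, with the step from compound 2 estimated as a 2.5-fold lower number from compound 2 to compound 4 (0.39 log units; beyond the scatter). The estimate for compound 4 is 600 nM, with a range from 200 nM to 1800 nM.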

Compound 4, half-maximal effective concentration: 948 nM
Compound 4: middle estimate off by 1.6-fold (0.20 log units), on the low side; the range from low to high includes it.
By their numbers in this assay, from the lowest: compound 3; then compounds 4 and 2 (each within the scatter of the next); then compound 1.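

In this assay, going by these compounds alone, the change from phenyl to 3-chlorophenyl gives a 1.6-fold lower number from compound 2 to compound 4 (0.19 log units; within the scatter), the first step that can be read at a single place. Within the data shown here, at this position, on an aromatic carbon meta to a large group, chloro in place of hydrogen therefore does not separate compound 4 from compound 2, a result the earlier compounds could not give, as none of them formed a single-place pair. No measurement at hand bears on the reason for this outcome.

This single step does not show whether chloro on another aromatic carbon of the same ring would give the same result, and it does not connect compound 4 with compound 1 or compound 3, which each differ from it in more than one place. It also leaves open whether a different group at this position, such as an amine, a carboxylic acid or a longer chain, would move the number beyond the scatter or leave it within.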